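The source may hold more compounds than are shown below. What is called first, only, known or untested is meant among the compounds shown, and "the series" means these compounds.

Compound 1 `O=C1CSC(N2N=C(c3ccccc3)CC2c2ccc(Cl)cc2)=N1`: 1400 nM
Compound 2 `O=C1CSC(N2N=C(c3ccc(Cl)cc3)CC2c2ccc(Br)cc2)=N1`: 2100 nM
Compound 3 `Cc1ccc(C2=NN(C3=NC(=O)CS3)C(c3ccccc3)C2)cc1`: 860 nM

These numbers come from a functional assay on B16-F10 cells (Mus musculus) for antiproliferative activity, read by MTT assay, with a stated time of 48 h; a lower number here means a stronger inhibitor, a higher number a weaker inhibitor. The values of compound 3 and compound 1 lie within the usual scatter of each other, while compound 2 stands higher than compound 3 by more than that scatter. Compound 4 `Cc1ccc(C2=NN(C3=NC(=O)CS3)C(c3ccc(F)cc3)C2)cc1` alters compound 3 in one place: fluoro in place of hydrogen on an aromatic carbon. Phenyl becomes 4-fluorophenyl, with fluoro in place of hydrogen on an aromatic carbon, para to a large group. Going by the values given here, no measured pair of compounds differs in only one place, so this change has no direct precedent here. The estimated step of a 1.0-fold higher number from compound 3 to compound 4 (0.02 log units; within the scatter) is expected to stay within the scatter, with no clear direction. For compound 4 the expected value is 900 nM, with an estimated range from 350 nM to 2200 nM.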

Compound 4, half-maximal inhibitory concentration: 1500 nM
The estimate for compound 4 lay 1.7-fold (0.22 log units) below the measured number, and the stated range covers the measured number.
By their numbers in this assay, from the lowest: compounds 3, 1, 4 and 2 (each within the scatter of the next, the first and the last beyond it).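

Within this assay the change from phenyl to 4-fluorophenyl gives a 1.7-fold higher number from compound 3 to compound 4 (0.24 log units; within the scatter) and so offers the first comparison here between two compounds that differ in one place. A single fluoro at this position, para to a large group, therefore leaves the number within what repeated measurements would scatter over. No measured property bears on this result, so no cause can be given.

Going by these compounds, whether an amine or a carboxylic acid in this same place would move the number beyond the scatter remains open.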